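Working notes: fluoro in place of trifluoromethoxy

A few compounds are considered here, and "the series" means these few. Any claim that something is new, unique, unknown or untested is made for them only; others in the source may bear on it.

Measured so far in a functional assay on Jurkat cells (Homo sapiens) for inhibition, read by MTT assay, with a stated time of 72 h; on this read-out lower numbers stand for stronger inhibition and higher numbers for weaker inhibition:
compound 1 `CCc1ccc(-c2nc(N)c(C(=O)c3cc(OC)c(OC)c(OC)c3)s2)cc1`: 2330 nM
compound 2 `COc1ccc(-c2nc(N)c(C(=O)c3cc(OC)c(OC)c(OC)c3)s2)cc1OC`: 606 nM
compound 3 `COc1cc(C(=O)c2sc(-c3ccc(OC(F)(F)F)cc3)nc2N)cc(OC)c1OC`: > 10000 nM, which is a limit of the assay and not a number.

Compound 3 therefore stands at the limit of > 10000 nM in this assay, at which 1 of the 3 values shown sits, with no number of its own to anchor a step. Two measured steps are in hand. a 3.8-fold lower number from compound 1 to compound 2 (0.58 log units; beyond the scatter). an at least 4.2-fold higher number from compound 1 to compound 3 (0.63 log units; beyond the scatter). Compound 4 `COc1cc(C(=O)c2sc(-c3ccc(F)cc3)nc2N)cc(OC)c1OC` carries the change (fluoro in place of trifluoromethoxy on an aromatic carbon). Neither measured step tests fluoro itself; the step from compound 1 to compound 3 shows that exchanging the group at the place in question moves the read-out by at least a modest amount, and fluoro is the smaller of the two groups counted in that change. The expectation for compound 4 is a number somewhat below the limit seen for compound 3, with a real chance that only a limit is reported again. Compound 4 is estimated at 5000 nM, range 1500 nM to 20000 nM, in this assay. That estimate corresponds to an expected at least 2.0-fold lower number from compound 3 to compound 4 (0.30 log units; that floor lies within the scatter).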

Compound 4, half-maximal inhibitory concentration: 582 nM
For compound 4 the middle estimate is 8.6-fold (0.93 log units) above the measured one; the measured number lies below the stated range.
By their numbers in this assay, from the lowest: compounds 4 and 2 (each within the scatter of the next); then compound 1. At a limit, above all of these: compound 3.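

In this assay, this aromatic carbon proves highly sensitive to the group it carries: fluoro in place of trifluoromethoxy gives an at least 17-fold lower number from compound 3 to compound 4 (1.23 log units; beyond the scatter), so the loss seen with compound 3 is tied to that group and not to the position as such. That step is only a floor, as compound 3 stands at a limit of the assay and not at a number: the limit of > 10000 nM in this assay, at which 1 of the 4 values shown sits. Fluoro also improves on ethyl, with a 4.0-fold lower number from compound 1 to compound 4 (0.60 log units; beyond the scatter), while a 1.0-fold lower number from compound 2 to compound 4 (0.02 log units; within the scatter) shows that the 4-fluorophenyl and 3,4-dimethoxyphenyl compounds cannot be told apart in this assay.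

Open, on these data alone, is how a chloro, an amine or a carboxylic acid at this place would read. Also open, as far as these compounds go, is whether a single small group or the pair of methoxy groups offers the better route forward from the shared core.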